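The compounds below may be only part of what the source reports. "The series", "measured", "known", "first", "only" and "open" are said of these compounds alone.

Measured compounds: compound 1 `COc1ccc(CN(C(=O)C2CC2)c2cc(OC)c(OC)c(OC)c2)cc1O` with 80 nM; compound 2 `COc1ccc(N(Cc2cc(OC)c(OC)c(OC)c2)C(=O)CCl)cc1O` with 29800 nM.

Both were tested in a functional assay on KYSE-450 cells (Homo sapiens) for inhibition, read by MTT assay, with a stated time of 48 h; a lower number here means a stronger inhibitor, a higher number a weaker inhibitor. Compound 1 stands as the lower of the two numbers, and compound 2 sits far above it, beyond the scatter. Among the measured compounds shown here, no single-site step connects them, so their two values alone are what is known.

Compound 3 `COc1ccc(CN(C(=O)CCCCCl)c2cc(OC)c(OC)c(OC)c2)cc1O` differs from compound 1 by the change (4-chlorobutyl in place of cyclopropyl on a carbonyl carbon). For the measured compounds named here, with no measured step to guide it, compound 3 is expected to be a weaker inhibitor, by a moderate step of a 3.8-fold higher number from compound 1 to compound 3 (0.57 log units; beyond the scatter). Compound 3 is estimated at 300 nM, with a range from 80 nM to 1500 nM.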

Compound 3, half-maximal inhibitory concentration: 770 nM
Estimate against measurement, compound 3: 2.6-fold (0.41 log units) below; the measured number falls inside the stated range.
By their numbers in this assay, from the lowest: compound 1; then compound 3; then compound 2.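

With 4-chlorobutyl in place of cyclopropyl on a carbonyl carbon whose other neighbour is an amide-type nitrogen, this assay gives a 9.6-fold higher number from compound 1 to compound 3 (0.98 log units; beyond the scatter). Among the compounds shown here, this is the first single-place comparison, and it shows that the group on this carbonyl carbon affects the read-out, with cyclopropyl giving the stronger inhibitor of this pair. Nothing available explains this difference. The compounds shown do not separate the loss of the ring from the added chain length or the chlorine. A plain butyl chain, a cyclobutyl group or a shorter chloropropyl chain on this carbonyl carbon would each bear on that question.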